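The source may hold more compounds than are shown below. What is called first, only, known or untested is meant among the compounds shown, and "the series" means these compounds.

Within the data shown here, compound 1 `CCCCCCS(=O)(=O)N[C@H]1C2CC[C@H](C2)[C@@H]1C/C=C\CCCC(=O)O` gives 13300 nM in a functional assay (plasma) for inhibition, with Oryctolagus cuniculus as the target (on this read-out lower numbers stand for stronger inhibition and higher numbers for weaker inhibition), the only numeric value in hand. Compound 2 `O=C(O)CCC/C=C\C[C@H]1[C@@H]2CCC(C2)[C@@H]1NC(=O)c1ccccc1` reaches only a limit of the assay, > 800000 nM, so the limit of > 800000 nM in this assay, at which 1 of the 2 values shown sits, is where the second value sits. Compound 3 `O=C(O)CCC/C=C\C[C@H]1[C@@H]2CCC(C2)[C@@H]1NS(=O)(=O)c1cccc2ccccc12` differs from compound 1 in one place (naphthalen-1-yl in place of hexyl on a sulfonyl sulfur). Among the measured compounds shown here, no measured step between two compounds is known, so the size of this change can only be expected. Compound 3 is estimated at 1500 nM, a range from 150 nM to 15000 nM, meaning an expected step of an 8.9-fold lower number from compound 1 to compound 3 (0.95 log units; beyond the scatter) beyond the usual scatter toward stronger inhibition.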

Compound 3, half-maximal inhibitory concentration: 1100 nM
The estimate for compound 3 lay 1.4-fold (0.13 log units) above the measured number, and the stated range covers the measured number.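

Replacing hexyl with naphthalen-1-yl on the sulfonyl sulfur gives a 12-fold lower number from compound 1 to compound 3 (1.08 log units; beyond the scatter) in this assay. This first measured step shows that the group at this place can shift the read-out well beyond the scatter, and that a chain is not needed there, since two aromatic rings are accepted and give stronger inhibition. Nothing in hand explains the size of this step. On these data alone, it remains open whether a naphthalen-2-yl group, a butyl chain or a chlorophenyl group on the sulfur would do better or worse.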